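This account rests on a few compounds, and the source may have more. Where it says the series, first, only, none or still open, it means among the compounds named here.

Compound 1, `Cc1cccc2c1CC/C2=C\C(=O)NC1CC1` — in a functional assay on the whole organism with Rattus norvegicus as the target, at a dose of 20 mg/kg by the oral route (on this read-out higher numbers stand for more inhibition at the one dose given (going by the name of the read-out) and lower numbers for less inhibition), compound 1 gives 15%.
Compound 2, `CCNC(=O)/C=C1\CCc2ccc(F)cc21` — in this assay compound 2 gives 45%.
Compound 3, `NC(=O)/C=C1\CCc2c1ccc(F)c2F` — in this assay compound 3 gives 77%.

Of the three numbers, compound 2 stands second highest. Its nearest neighbour is compound 1, whose number lies lower by a gap beyond the usual scatter; the furthest is compound 3, whose number lies higher, again beyond the scatter. The three compounds differ from one another in more than one place, so these gaps show only what their values show and no single change can be read from them.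

Compound 4, `O=C(/C=C1\CCc2ccc(F)cc21)NC1CC1`, has not yet been measured. It keeps the core and the ring substitution of compound 2 and differs from it in one place:

cyclopropyl in place of ethyl on an amide-type nitrogen

Among the compounds with values here, no pair of measured compounds differs by exactly this change, so there is no measured step to lean on. With nothing in the data pointing one way or the other, the expected step from compound 2 to compound 4 in this assay is no change at the digits printed from compound 2 to compound 4 (within the scatter), that is, none beyond the scatter. Compound 4 is therefore expected to give about 45% in this assay, within a range from 25% to 65%.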

Compound 4, a percentage reported as inhibition, in the whole organism at one dose (the size of the read-out at that dose, not a potency): 5%
The estimate for compound 4 lay 40 percentage points above the measured number, outside the stated range (below it).
By their numbers in this assay, from the lowest: compounds 4 and 1 (each within the scatter of the next); then compound 2; then compound 3.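

Cyclopropyl in place of ethyl on the amide-type nitrogen is the first change in one place only that can be read in this assay, and it gives a number 40 percentage points lower from compound 2 to compound 4 (beyond the scatter) on that single exchange. On the counts the exchange looks small: ethyl has 2 heavy atoms and no ring, cyclopropyl has 3 heavy atoms in one three-membered ring, and neither brings a hydrogen-bond donor, acceptor or net charge, yet the read-out is clearly sensitive to what sits at this position. Nothing among the data offers a measured reason for this drop.

The compounds shown cannot separate the effect of the extra carbon from that of the ring, which a propyl or isopropyl group on the same nitrogen would begin to do, while methyl or cyclobutyl would show whether the trend extends to smaller or larger groups. As far as these compounds go, whether the same exchange has a similar effect with other ring substituents on the core also stays open, since compound 1 and compound 3 each differ from compound 2 and compound 4 in more than one place.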